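This account rests on a few compounds, and the source may have more. Where it says the series, first, only, none or still open, it means among the compounds named here.

Measured compounds:
Compound 1, `Nc1nc(N)nc(-c2ccccc2Br)n1`: 26%
Compound 2, `CCc1ccccc1-c1nc(N)nc(N)n1`: 20%

The read-out is a functional assay on the whole organism with Rattus norvegicus as the target, at a dose of 20 mg/kg by the intraperitoneal route; a higher number here means more inhibition at the dose given (going by the name of the read-out), a lower number less inhibition. Among the two numbers, compound 2 stands lowest, with compound 1 as its nearest neighbour; the single measured step, a number 6 percentage points lower from compound 1 to compound 2 (within the scatter), is within the scatter, so the two compounds cannot be ranked against each other.

Compound 3, `CCOc1ccccc1-c1nc(N)nc(N)n1`, has not yet been measured. It differs from compound 2 in one place: ethoxy in place of ethyl on an aromatic carbon. Among the measured compounds shown here, the only measured step swaps bromo for ethyl and touches no oxygen, so it bears on this change only as a sign that a small group on this aromatic carbon has not shifted the result beyond the scatter. No step beyond the scatter is therefore expected in this assay.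

For compound 3 the expected step is a number 2 percentage points higher from compound 2 to compound 3 (within the scatter). Compound 3 is estimated at 22%, with a range from 5% to 40%.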

Compound 3, a percentage reported as inhibition, in the whole organism at one dose (the size of the read-out at that dose, not a potency): -5%
For compound 3 the middle estimate is 27 percentage points above the measured one, outside the stated range (below it).
By their numbers in this assay, from the lowest: compound 3; then compounds 2 and 1 (each within the scatter of the next).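

In this assay, the group on this aromatic carbon turns out to matter: ethoxy in place of ethyl gives a number 25 percentage points lower from compound 2 to compound 3 (beyond the scatter), and ethoxy in place of bromo gives a number 31 percentage points lower from compound 1 to compound 3 (beyond the scatter), whereas the swap of bromo for ethyl had stayed within the scatter. So this position does not accept every small group alike, and compound 3, at -5%, stands apart from the other two, with an oxygen attached to the aromatic carbon that neither of them has. Nothing available explains why this change lowers the number.

The compounds shown leave open whether the drop goes with that oxygen or with the longer chain, which a methoxy or a propyl group on this carbon would help to separate. They also leave open how a hydroxyl or an amine would behave here.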